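A few compounds are considered here, and "the series" means these few. Any claim that something is new, unique, unknown or untested is made for them only; others in the source may bear on it.

Within this set, compound 3 `CS(=O)(=O)CCNc1nc(-c2ccc3ncnc(Nc4ccc(OCc5ccccc5)cc4)c3c2)cs1` gives the highest number in an in vivo ADME assay on the whole organism for pharmacokinetics, with Mus musculus as the target (a lower number here means that a smaller share of the oral dose reaches the circulation, a higher number that a larger share of the oral dose reaches the circulation), 66.6%. Compound 2 `CS(=O)(=O)CCNc1nc(-c2ccc3ncnc(Nc4ccc(OCc5cccc(F)c5)c(Cl)c4)c3c2)cs1` stands nearest with 39.5%, and compound 1 `CS(=O)(=O)CCNc1nc(-c2ccc3ncnc(Nc4ccc5c(cnn5Cc5ccccc5)c4)c3c2)cs1` furthest with 11%, both gaps lying beyond the scatter. Compound 4 `CS(=O)(=O)CCNc1nc(-c2ccc3ncnc(Nc4ccc(OCc5ccccc5)c(Cl)c4)c3c2)cs1` differs from compound 3 by chloro in place of hydrogen on an aromatic carbon, ortho to the benzyloxy group. Among the measured compounds shown here, no single-change step between measured compounds is available, so the size of this change must be guessed from the set as a whole: compound 2 carries the same chloro together with a fluorine on its benzyl group and gives 39.5%. A downward step beyond the scatter is therefore expected, a number 21.6 percentage points lower from compound 3 to compound 4 (beyond the scatter). Compound 4 is estimated at 45%, with a range from 25% to 68%.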

Compound 4, oral bioavailability: 16.6%
Compound 4: the middle estimate sits 28.4 percentage points above what was measured; measured number outside the range, below it.
By their numbers in this assay, from the lowest: compounds 1 and 4 (each within the scatter of the next); then compound 2; then compound 3.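

In this assay, chloro in place of hydrogen, ortho to a benzyloxy group, carries a large cost on its own: a number 50 percentage points lower from compound 3 to compound 4 (beyond the scatter). With that chloro present, the fluoro on the benzyl group also counts, since hydrogen in its place gives a number 22.9 percentage points lower from compound 2 to compound 4 (beyond the scatter). No measurement at hand accounts for either step. From the compounds shown here alone, whether fluoro gives a similar step without the chloro stays open. So does whether a methyl or a methoxy in the place of the chloro would give a step of the same size.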